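From methoxycarbonyl to carbamoyl on a shared core

This account rests on a few compounds, and the source may have more. Where it says the series, first, only, none or still open, it means among the compounds named here.

Three compounds share a core and differ in the group on one aromatic carbon. In a functional assay on NCI-H1993 cells (Homo sapiens) for inhibition, read by CCK-8 assay, with a stated time of 72 h (a lower number here means a stronger inhibitor, a higher number a weaker inhibitor), compound 1 `CC(c1cc2cccnc2cc1F)n1cnc2ncc(-c3cn[nH]c3)nc21`, carrying 1H-pyrazol-4-yl, gives 187 nM, and compound 2 `CC(c1cc2cccnc2cc1F)n1cnc2ncc(-c3ccncc3)nc21`, carrying pyridin-4-yl, gives 171 nM. These two lie within the scatter of each other, with a 1.1-fold lower number from compound 1 to compound 2 (0.04 log units; within the scatter). Compound 3 `COC(=O)c1ccc(-c2cnc3ncn(C(C)c4cc5cccnc5cc4F)c3n2)cc1F`, carrying 3-fluoro-4-(methoxycarbonyl)phenyl, gives 60.2 nM, the strongest inhibition of the three in this assay. The steps that reach it are modest: a 3.1-fold lower number from compound 1 to compound 3 (0.49 log units; beyond the scatter), and a 2.8-fold lower number from compound 2 to compound 3 (0.45 log units; beyond the scatter).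

Compound 4 `CC(c1cc2cccnc2cc1F)n1cnc2ncc(-c3ccc(C(N)=O)c(F)c3)nc21` has not yet been measured. It alters one part of that group: amino in place of methoxy on a carbonyl carbon, with amino in place of methoxy on a carbonyl carbon, so that methoxycarbonyl becomes carbamoyl. Going by the values given here, no measured step makes this exchange, so the data offer only indirect guidance. Replacing the whole group gave only modest changes, as in a 2.8-fold lower number from compound 2 to compound 3 (0.45 log units; beyond the scatter), and a smaller edit within the group of compound 3 is therefore expected to move the number no further than the scatter. The estimated change is a 1.2-fold lower number from compound 3 to compound 4 (0.08 log units; within the scatter). The estimate for compound 4 is 50 nM, with an expected range from 15 nM to 170 nM.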

Compound 4, half-maximal inhibitory concentration: 19.5 nM
Compound 4: middle estimate off by 2.6-fold (0.41 log units), on the high side; measured number inside the range.
By their numbers in this assay, from the lowest: compound 4; then compound 3; then compounds 2 and 1 (each within the scatter of the next).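

In this assay, going by these compounds alone, exchanging methoxy for amino on the carbonyl carbon gives a 3.1-fold lower number from compound 3 to compound 4 (0.49 log units; beyond the scatter) and so shows what the earlier compounds could not: an edit confined to the carbonyl substituent, with the 3-fluorophenyl part of the group unchanged, moves the number beyond the scatter. The earlier steps shown here replaced the whole group, whereas this one shows that the result at this aromatic carbon also depends on what the carbonyl carbon carries, and it makes compound 4 the strongest inhibitor of the four, with an 8.8-fold lower number from compound 2 to compound 4 (0.94 log units; beyond the scatter) and a 9.6-fold lower number from compound 1 to compound 4 (0.98 log units; beyond the scatter) as its steps from the two smaller groups. Nothing in the material shown accounts for the effect of this exchange.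

The compounds shown leave open whether other groups on the same carbonyl carbon, such as hydroxy, which would give a carboxylic acid, or methylamino or dimethylamino, would follow amino or methoxy in this assay. They also leave open what the fluorine contributes, as both phenyl compounds carry it and a plain 4-carbamoylphenyl group stands outside the set.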